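The compounds below may be only part of what the source reports. "The series", "measured", "known", "first", "only" and "open" are said of these compounds alone.

Among the compounds with values here, compound 3 `COc1cc2c(Nc3nc4ccc(C(=O)Nc5c(C)cc(C)cc5C)cc4s3)ncnc2cc1OCCCN1CCCCC1C` gives the lowest number of the three measured so far: in a functional assay on U-937 cells (Homo sapiens) for cytotoxicity, read by WST assay, with a stated time of 72 h (a lower number here means a stronger inhibitor, a higher number a weaker inhibitor), compound 3 gives 3600 nM. Within the data shown here, compound 1 `CCN(CC)CCCOc1cc2ncnc(Nc3nc4ccc(C(=O)Nc5c(C)cccc5C)cc4s3)c2cc1OC` gives 23700 nM and compound 2 `COc1cc2c(Nc3nc4ccc(C(=O)Nc5c(C)cccc5C)cc4s3)ncnc2cc1OCCCN1CCCCC1` gives 14700 nM; the only single-site step measured, a 1.6-fold lower number from compound 1 to compound 2 (0.21 log units; within the scatter), concerns a different site and stays within the scatter. Compound 4 `COc1cc2c(Nc3nc4ccc(C(=O)Nc5c(C)cccc5C)cc4s3)ncnc2cc1OCCCN1CCCCC1C` differs from compound 3 by hydrogen in place of methyl on an aromatic carbon. Among the measured compounds shown here, no measured step bears directly on this change. Compound 2 and compound 3 differ at two places, one of them this methyl, and their values sit beyond the scatter apart, so some part of that gap may come from here. For compound 4 a modest rise in number is expected, a 1.9-fold higher number from compound 3 to compound 4 (0.29 log units; within the scatter). Compound 4 is estimated at 7000 nM, with a range of 2500 nM to 20000 nM.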

Compound 4, half-maximal inhibitory concentration: 10800 nM
Estimate against measurement, compound 4: 1.5-fold (0.19 log units) below; low and high end bracket the measured number.
By their numbers in this assay, from the lowest: compound 3; then compounds 4, 2 and 1 (each within the scatter of the next, the first and the last beyond it).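

Within the data shown here, the change from 2,4,6-trimethylphenyl to 2,6-dimethylphenyl gives the first single-site reading at this aromatic carbon: in this assay it gives a 3.0-fold higher number from compound 3 to compound 4 (0.48 log units; beyond the scatter), so the methyl there counts. On the chain side, the methyl on the saturated ring carbon gives a 1.4-fold lower number from compound 2 to compound 4 (0.13 log units; within the scatter), while 2-methylpiperidin-1-yl in place of diethylamino gives a 2.2-fold lower number from compound 1 to compound 4 (0.34 log units; beyond the scatter). No available evidence explains these steps.

On these data alone, whether methoxy or chlorine at this aromatic carbon would match methyl stays open. Also open, as far as these compounds go, is whether the methyl step holds with piperidin-1-yl or diethylamino on the chain.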